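The source may report more compounds than this note shows. Statements on the series, on what has been measured and on what is new or still open speak of the compounds shown alone.

Measured in a functional assay (mast cells) for inhibition, with Rattus norvegicus as the target; on this read-out higher numbers stand for an effect only at larger amounts of compound and lower numbers for an effect already at smaller amounts:
- Compound 1 `CC1CC/C(=N\Nc2ccc(O)cc2)c2ncc(C(=O)O)c(=O)n21`: 1300 nM
- Compound 2 `Cc1ccc(N/N=C2\CCC(C)n3c2ncc(C(=O)O)c3=O)cc1`: 280 nM
- Compound 3 `CC1CC/C(=N\Nc2ccc(C(F)(F)F)cc2)c2ncc(C(=O)O)c(=O)n21`: 280 nM

Compound 3 shares the lowest of the three numbers with compound 2, and compound 1 has the highest. The next compound to be tested is compound 4 `CC1CC/C(=N\Nc2ccc([N+](=O)[O-])cc2)c2ncc(C(=O)O)c(=O)n21`, which carries nitro in place of trifluoromethyl on an aromatic carbon.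

Three measured steps at this same aromatic carbon bear on the change. Replacing hydroxy gave a 4.6-fold lower number from compound 1 to compound 2 (0.67 log units; beyond the scatter) and a 4.6-fold lower number from compound 1 to compound 3 (0.67 log units; beyond the scatter), both modest. Exchanging the two groups that followed gave no change at the digits printed from compound 2 to compound 3 (within the scatter). None of these steps involves nitro, so the data offer only an indirect guide. Taking the last step as the closest precedent, no shift beyond the scatter is expected in this assay. The expected step is a 1.1-fold lower number from compound 3 to compound 4 (0.05 log units; within the scatter). For compound 4 the estimated value is 250 nM, with an expected range of 100 nM to 700 nM.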

Compound 4, half-maximal effective concentration: 8900 nM
For compound 4 the middle estimate is 36-fold (1.55 log units) below the measured one; measured number above the stated range.
By their numbers in this assay, from the lowest: compounds 2 and 3 (each within the scatter of the next); then compound 1; then compound 4.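

In this assay this aromatic carbon, para to a large group, turns out not to accept every replacement, since nitro gives a 32-fold higher number from compound 3 to compound 4 (1.50 log units; beyond the scatter) and also a 32-fold higher number from compound 2 to compound 4 (1.50 log units; beyond the scatter) in a series where methyl and trifluoromethyl had stood level. Hydroxy had marked the high end of the series until now, yet nitro gives a 6.8-fold higher number from compound 1 to compound 4 (0.84 log units; beyond the scatter) and so compound 4 has the highest number of the four, which widens the span of effects seen at this one carbon. Nothing at hand accounts for the gap between nitro and the other three groups.

The compounds shown leave open whether this large rise belongs to nitro alone or would also appear with a nitrile, an amine or a carboxylic acid at the same carbon. They also leave open whether nitro would behave the same way elsewhere on this ring.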